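The compounds below may be only part of what the source reports. "The series", "measured", "known", "first", "only" and "open" are said of these compounds alone.

Going by the values given here, in a functional assay on aorta (Rattus norvegicus, strain Wistar) (on this read-out lower numbers stand for stronger inhibition and higher numbers for weaker inhibition), compound 1 (`CC(=O)c1ccc2c(c1)N(C1=CCCC1=O)CC(C)(C)S2`) gives 1.45 nM, the lower of the two numbers measured so far. Compound 2 (`CC1(C)CSc2ccc(C(F)(F)F)cc2N1C1=CCCC1=O`) gives 66.1 nM, a much higher number and a gap well beyond the usual scatter of repeated measurements. Compound 3 (`CCc1ccc2c(c1)N(C1=CCCC1=O)CC(C)(C)S2`) keeps the core of compound 1 but has ethyl in place of acetyl on an aromatic carbon. Among the compounds with values here, no measured pair shows what this exchange does, so any forecast here is a judgement. With compound 1 already at 1.45 nM, a change at this place seems more likely to raise the number than to lower it. Weaker inhibition is therefore expected, by a step beyond the scatter: the estimated change is a 14-fold higher number from compound 1 to compound 3 (1.14 log units; beyond the scatter). Compound 3 is expected to give 20 nM, with an estimated range of 4 nM to 100 nM.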

Compound 3, half-maximal inhibitory concentration: 155 nM
The estimate for compound 3 lay 7.8-fold (0.89 log units) below the measured number, outside the stated range (above it).
By their numbers in this assay, from the lowest: compound 1; then compound 2; then compound 3.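

In this assay, going by these compounds alone, replacing acetyl with ethyl on this aromatic carbon gives a 110-fold higher number from compound 1 to compound 3 (2.03 log units; beyond the scatter), and this is the first comparison of two compounds that differ in only one place. It shows that the group at this position strongly affects the read-out, and that ethyl does not stand in for acetyl here, even though the rest of the molecule is unchanged. Acetyl carries a carbonyl, which counts as a hydrogen-bond acceptor, while ethyl has no acceptor and is the smaller group, but no data shown here tell which of these differences accounts for the large rise.

On these data alone, it remains open whether a propanoyl group, an amide or a nitrile at this position would keep a number close to that of compound 1. As far as these compounds go, it is also open whether the same exchange would have a similar effect on a different core.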